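The source may hold more compounds than are shown below. What is called first, only, known or untested is meant among the compounds shown, and "the series" means these compounds.

Measured compounds:
- compound 1, `CC1=C(O)c2c(oc(-c3cc(C)cc(C)c3)cc2=O)C(C)(C)C1=O`: 53.1 ug/mL
- compound 2, `CCC1=C(O)c2c(oc(-c3ccccc3)cc2=O)C(CC)(CC)C1=O`: > 80 ug/mL

In a functional assay on KB cells (Homo sapiens) for cytotoxicity, read by sulforhodamine B assay (on this read-out lower numbers stand for an effect already at smaller amounts and higher numbers for an effect only at larger amounts of compound), compound 1 gives 53.1 ug/mL. For compound 2 the read-out is a limit of the assay and not a number, reported as > 80 ug/mL. Compound 2 therefore stands at the limit of > 80 ug/mL in this assay, at which 1 of the 2 values shown sits, so where it sits in this assay is open above that figure; of the two measured compounds, compound 1 has a number and compound 2 has only a limit, and nothing more can be read from the pair.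

Compound 3, `CCC1=C(O)c2c(oc(-c3ccccc3C)cc2=O)C(CC)(CC)C1=O`, differs from compound 2 by methyl in place of hydrogen on an aromatic carbon, the phenyl becoming 2-methylphenyl. Going by the values given here, no measured step in this assay bears on such a change, so the expectation rests on compound 2 alone. The step of a number no higher from compound 2 to compound 3 (the limit leaves the size open) is expected to be none beyond the scatter, in either direction. Compound 3 is estimated at 80 ug/mL, with a range from 30 ug/mL to 200 ug/mL, and it is expected that this assay again reports only a limit for compound 3 rather than a number.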

Compound 3, concentration for half-maximal effect: 18 ug/mL
For compound 3 the middle estimate is 4.4-fold (0.65 log units) above the measured one; measured number below the stated range.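

In this assay, the change from phenyl to 2-methylphenyl, with methyl in place of hydrogen on an aromatic carbon ortho to a large group, gives an at least 4.4-fold lower number from compound 2 to compound 3 (0.64 log units; beyond the scatter), so this position on the ring responds to even a single added carbon. The read-out of compound 2 is a limit of the assay and not a number: the limit of > 80 ug/mL in this assay, at which 1 of the 3 values shown sits. The step therefore fixes only a minimum size, but compound 3 now gives a number on the core of compound 2 against which further changes on this ring can be read.

As far as these compounds go, whether methyl at another carbon of the same ring would have a comparable effect remains open, as does whether ethyl, methoxy, chloro or an amine at this same carbon would give a number lower or higher than that of compound 3. Compound 1 differs from compound 3 in more than one place, so the pair cannot separate the contribution of the aryl group from that of the alkyl groups on the core.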